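From ethynyl to benzamido near a cytotoxicity limit

The source may report more compounds than this note shows. Statements on the series, on what has been measured and on what is new or still open speak of the compounds shown alone.

For the measured compounds named here, in a functional assay on HepG2 cells (Homo sapiens) for cytotoxicity, read by MTT assay, with a stated time of 72 h (a lower number here means a stronger inhibitor, a higher number a weaker inhibitor), compound 1 (`C#Cc1cccc(Nc2nc3cnc(Nc4ccc(N5CCN(C)CC5)cc4)nc3n2C2CCCC2)c1`) gives 4900 nM and holds the only actual number among the three compounds measured. Compound 2 (`CN1CCN(c2ccc(Nc3ncc4nc(Nc5ccc(Br)cc5)n(C5CCCC5)c4n3)cc2)CC1`) is reported only as a limit (> 5000 nM) and not as a number. Compound 3 (`CN1CCN(c2ccc(Nc3ncc4nc(Nc5cc(Cl)ccc5Cl)n(C5CCCC5)c4n3)cc2)CC1`) is likewise reported only as a limit (> 5000 nM) and not as a number. The number for compound 1 therefore stands close to the limit of > 5000 nM in this assay, at which 2 of the 3 values shown sit, and leaves little room for reading a trend.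

Compound 4 (`CN1CCN(c2ccc(Nc3ncc4nc(Nc5cccc(NC(=O)c6ccccc6)c5)n(C5CCCC5)c4n3)cc2)CC1`) has benzamido in place of ethynyl on an aromatic carbon and otherwise matches compound 1. The nearest evidence comes from two replacements of the 3-ethynylphenyl group. One is an at least 1.0-fold higher number from compound 1 to compound 2 (0.00 log units; that floor lies within the scatter) and the other is an at least 1.0-fold higher number from compound 1 to compound 3 (0.00 log units; that floor lies within the scatter) and both are floors rather than measured sizes. Neither step involves benzamido, so they offer only a weak guide, and no step beyond the scatter is expected in this assay in either direction.

For compound 4 the expected step is a 1.1-fold lower number from compound 1 to compound 4 (0.04 log units; within the scatter) and is estimated to stay within the scatter. For compound 4 the estimate is 4500 nM with an expected range from 1500 nM to 10000 nM and the result may well arrive as a limit.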

Compound 4, half-maximal inhibitory concentration: 2600 nM
Compound 4: the middle estimate sits 1.7-fold (0.24 log units) above what was measured; the range from low to high includes it.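

For the compounds shown here, at this position, the earlier replacements gave only floors, so compound 4 provides the first step in this assay that joins two actual numbers: a 1.9-fold lower number from compound 1 to compound 4 (0.28 log units; within the scatter). The change is large in structure, since benzamido brings a six-membered aromatic ring, a carbonyl and an amide hydrogen where ethynyl had none of these, yet the step does not go beyond the scatter. Compound 4 and compound 1 therefore cannot be told apart here, and the actual numbers for these two compounds stand in a small set that also contains limits: the limit of > 5000 nM in this assay, at which 2 of the 4 values shown sit.

The compounds shown leave open whether a smaller acetamido group, a dimethylamino group or a carboxylic acid on the same aromatic carbon would give a step beyond the scatter, and which part of benzamido, if any, bears on the number. The step between compound 2 and compound 3 cannot be read, so these two compounds add no size to compare with the step to benzamido.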